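The source may hold more compounds than are shown below. What is called first, only, known or untested is meant among the compounds shown, and "the series" means these compounds.

Compound 1 `COc1ccc(SCc2ccc(/C=C/C(=O)Nc3ccccc3N)cc2)cc1OC`: 10.1%
Compound 2 `Nc1ccccc1NC(=O)/C=C/c1ccc(CSc2ccc(Cl)cc2)cc1`: 1.94%
Compound 3 `Nc1ccccc1NC(=O)/C=C/c1ccc(CSc2cccc3ccccc23)cc1`: 20.6%

Three compounds share a core and differ only in the group carried on the sulfur. In a functional assay on HeLa cells (Homo sapiens) for inhibition, read by CCK-8 assay, with a stated time of 72 h, tested at 2 uM (a higher number here means more inhibition of growth at the concentration tested, a lower number less inhibition of growth), compound 3 stands highest of the three: compound 1 is the nearest, with a number 10.5 percentage points higher from compound 1 to compound 3 (beyond the scatter), and compound 2 the furthest, with a number 18.7 percentage points higher from compound 2 to compound 3 (beyond the scatter). The step between the two lower compounds, a number 8.2 percentage points lower from compound 1 to compound 2 (within the scatter), does not rise above the scatter, so the numbers show one group that stands apart and two that cannot be told from one another.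

Compound 4 `Nc1ccccc1NC(=O)/C=C/c1ccc(CSc2ccc(C(F)(F)F)cn2)cc1` is the next step from compound 3. The change is 5-(trifluoromethyl)pyridin-2-yl in place of naphthalen-1-yl on a sulfur. All three measured steps bear on it, since each swaps the group on the same sulfur. The two steps that reached naphthalen-1-yl were the only ones beyond the scatter, and both went up; the step between the two single-ring groups stayed within it. Compound 4 returns to a single six-membered aromatic ring, so a drop of modest size, a number 13.6 percentage points lower from compound 3 to compound 4 (beyond the scatter), is expected, landing near compounds 1 and 2. Compound 4 is therefore estimated at 7% in this assay, within a range from -4% to 18%.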

Compound 4, percent growth inhibition at one concentration: 6.07%
Beside the measured number, compound 4's estimate is 0.9 percentage points above it; low and high end bracket the measured number.
By their numbers in this assay, from the lowest: compounds 2, 4 and 1 (each within the scatter of the next); then compound 3.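

In this assay, 5-(trifluoromethyl)pyridin-2-yl and naphthalen-1-yl carry the same number of heavy atoms, yet the swap gives a number 14.5 percentage points lower from compound 3 to compound 4 (beyond the scatter) on the same sulfur, so heavy atom count alone does not set the number at this position. The ring hetero atom, the hydrogen-bond acceptor and the trifluoromethyl group leave compound 4 indistinguishable from the other two single-ring compounds, with a number 4.1 percentage points higher from compound 2 to compound 4 (within the scatter) and a number 4 percentage points lower from compound 1 to compound 4 (within the scatter) as the steps that show it. Among these four compounds, only the group with two aromatic rings stands apart and none goes against that pattern, though nothing measured here gives a reason for it.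

The compounds shown leave open whether the second ring itself matters, which a two-ring group holding a ring nitrogen, such as quinolin-2-yl, or a saturated ring, such as cyclohexyl, on the same sulfur could help to settle. They also leave open how these compounds would compare at other concentrations, since each has a number at one concentration only.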